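The compounds below may be only part of what the source reports. "The series", "measured", "known", "first", "only" and "open" are said of these compounds alone.

Working notes on the series.

The shared core is carried unchanged by compound 1 `COc1cc(Cl)cc(-c2nn(-c3cccc(NC(=O)Nc4ccc(Cl)c(C(F)(F)F)c4)c3)cc2-c2ccncc2)c1`, compound 2 `COc1cc(Cl)cc(-c2nn(-c3cccc(NC(=O)Nc4ccc(Cl)c(Cl)c4)c3)cc2-c2ccncc2)c1` and compound 3 `COc1cc(Cl)cc(-c2nn(-c3cccc(NC(=O)Nc4cccc(C(F)(F)F)c4)c3)cc2-c2ccncc2)c1`; the three differ only in the aryl group attached to the urea. In a functional assay on RXF 393 cells (Homo sapiens) for inhibition, read by sulforhodamine B assay, with a stated time of 48 h, tested at 0.01 uM (a lower number here means a stronger effect, a higher number a weaker effect of the compound at the concentration tested), compound 1 gives 97%, compound 2 gives 100% and compound 3 gives 93%. Compound 3 holds the lowest of the three numbers, but the spread is small: a number 4 percentage points lower from compound 1 to compound 3 (within the scatter) and a number 7 percentage points lower from compound 2 to compound 3 (within the scatter), and likewise a number 3 percentage points higher from compound 1 to compound 2 (within the scatter). All three compounds therefore sit together at a read-out that indicates little effect at this concentration.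

Compound 4 `COc1cc(Cl)cc(-c2nn(-c3cccc(NC(=O)c4cccc(C(F)(F)F)c4)c3)cc2-c2ccncc2)c1` is not yet measured. It differs from compound 3 in one place: 3-(trifluoromethyl)phenyl in place of (3-(trifluoromethyl)phenyl)amino on a carbonyl carbon. Among the compounds with values here, none of the measured steps touches this position; each of them exchanges a substituent on the terminal aryl ring while the urea is retained, and each stays within the scatter. Within the data shown here, there is thus no measured precedent for the loss of the amide-type nitrogen, and no basis to expect a step beyond the scatter in this assay in either direction.

The estimate for compound 4 is accordingly set close to compound 3, at 94% with a range from 80% to 105%, which means an expected step of a number 1 percentage points higher from compound 3 to compound 4 (within the scatter).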

Compound 4, a percentage reported as activity, at one concentration (the size of the read-out at that concentration, not a potency): 58%
Compound 4: the middle estimate sits 36 percentage points above what was measured, outside the stated range (below it).
By their numbers in this assay, from the lowest: compound 4; then compounds 3, 1 and 2 (each within the scatter of the next).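

In this assay, within the data shown here, removing the amide-type nitrogen from the urea gives a number 35 percentage points lower from compound 3 to compound 4 (beyond the scatter), the first change to move the read-out beyond the scatter, whereas the substituent exchanges on the terminal aryl ring among compounds 1, 2 and 3 all stayed within it. The position on the carbonyl carbon is therefore sensitive to this change, and the two other ureas point the same way, with a number 42 percentage points lower from compound 2 to compound 4 (beyond the scatter) and a number 39 percentage points lower from compound 1 to compound 4 (beyond the scatter), although each of these steps also changes the substituents on the terminal aryl ring. The data shown offer no evidence on why the loss of this nitrogen goes with a stronger effect.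

Going by these compounds, with a single amide in hand, it remains open whether the shift carries over to amides bearing the 3,4-dichlorophenyl or 4-chloro-3-(trifluoromethyl)phenyl groups, and the read-out at one concentration gives no potency for any of the compounds. On these data alone, it is also open how other links would behave at this position, such as a sulfonamide in place of the carbonyl or a longer carbon chain between the carbonyl and the aryl ring.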